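A 2-hydroxyethyl branch on compound 1

The source may hold more compounds than are shown below. What is called first, only, known or untested is meant among the compounds shown, and "the series" means these compounds.

Measured in a functional assay on L6 cells (Rattus norvegicus) for cytotoxicity; on this read-out higher numbers stand for weaker inhibition and lower numbers for stronger inhibition:
- compound 1 `O=c1ccn(CCCOC(c2ccccc2)(c2ccccc2)c2ccccc2)c(=O)[nH]1`: 34000 nM
- compound 2 `O=c1ccn(CCCCCCOC(c2ccccc2)(c2ccccc2)c2ccccc2)c(=O)[nH]1`: 44000 nM
- compound 3 `COC(=O)NCC(CCn1ccc(=O)[nH]c1=O)COC(c1ccccc1)(c1ccccc1)c1ccccc1`: 15000 nM

Compound 1 lies within the scatter of compound 2, and the two stand clear of compound 3, which gives the lowest number. Compound 4 `O=c1ccn(CC(CCO)COC(c2ccccc2)(c2ccccc2)c2ccccc2)c(=O)[nH]1` is still unmeasured. It differs from compound 1 by 2-hydroxyethyl in place of hydrogen on a saturated chain carbon bound to two saturated chain carbons. Within the data shown here, the one measured step, a 1.3-fold higher number from compound 1 to compound 2 (0.11 log units; within the scatter), concerns the chain and not a branch, so it guides only loosely. Compound 3 also carries a branch and gives 15000 nM, which suggests a slight lean downward. The estimated change in this assay is a 1.2-fold lower number from compound 1 to compound 4 (0.08 log units; within the scatter), no step beyond the scatter. For compound 4 the expected value is 28000 nM, with an estimated range of 12000 nM to 60000 nM.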

Compound 4, half-maximal inhibitory concentration: 57000 nM
Compound 4: middle estimate off by 2.0-fold (0.31 log units), on the low side; measured number inside the range.
By their numbers in this assay, from the lowest: compound 3; then compounds 1, 2 and 4 (each within the scatter of the next).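

In this assay, 2-hydroxyethyl in place of hydrogen on a saturated chain carbon bound to two saturated chain carbons gives a 1.7-fold higher number from compound 1 to compound 4 (0.22 log units; within the scatter). Among these compounds, the earlier steps concerned only the chain, so this is the first direct reading of a substituent at this position, and this one does not carry the number beyond the scatter. Nothing available accounts for this result. From the compounds shown here alone, whether an amine, a carboxylic acid or a longer chain on the same carbon would move the number beyond the scatter remains open.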